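The compounds below may be only part of what the source reports. "The series", "measured", "known", "first", "only" and "open" are said of these compounds alone.

In a functional assay on Caco-2 cells (Homo sapiens) for inhibition, read by sulforhodamine B assay, with a stated time of 72 h (on this read-out higher numbers stand for weaker inhibition and lower numbers for stronger inhibition), the three measured compounds stand as follows.

Compound 1 `CCC(C)NC(=C\C(=O)/C=C/c1ccc(O)c(OC)c1)/C=C/c1ccc(O)c(OC)c1` gives > 25000 nM, a limit of the assay and not a number.
Compound 2 `COc1cc(/C=C/C(=O)/C=C(/C=C/c2ccc(OC(C)=O)c(OC)c2)NCC(C)C)ccc1OC(C)=O` gives > 25000 nM, likewise a limit.
Compound 3 `COc1cc(/C=C/C(=O)/C=C(/C=C/c2ccc(O)c(OC)c2)NCC(C)C)ccc1O` gives > 25000 nM, again a limit.

Compound 1 and compound 3 share a core and differ by sec-butyl in place of isobutyl on an amine nitrogen. The step that the two limits leave unreadable from compound 3 to compound 1 cannot be read, because both ends sit at the limit of > 25000 nM in this assay, at which 3 of the 3 values shown sit. Compound 2 carries a different core from compound 3; the difference between the two cores is not broken down here.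

Compound 4 `CCC(C)NC(=C\C(=O)/C=C/c1ccc(OC(C)=O)c(OC)c1)/C=C/c1ccc(OC(C)=O)c(OC)c1` is not yet measured. It differs from compound 2 by sec-butyl in place of isobutyl on an amine nitrogen, the same change that turns compound 3 into compound 1, made on the core of compound 2. Since the corresponding step that the two limits leave unreadable from compound 3 to compound 1 was hidden by the limit and compound 2 itself sits at a limit, there is no measured size to carry over. Compound 4 is therefore expected to stay at the limit as well, a step that the limit leaves unreadable from compound 2 to compound 4, and its estimated value in this assay is 40000 nM, with a range from 15000 nM to 150000 nM.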

Compound 4, half-maximal inhibitory concentration: 24000 nM
Estimate against measurement, compound 4: 1.7-fold (0.22 log units) above; measured number inside the range.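

Carried onto the acetate-bearing core, sec-butyl in place of isobutyl on an amine nitrogen gives an at least 1.0-fold lower number from compound 2 to compound 4 (0.01 log units; that floor lies within the scatter) in this assay. Within the data shown here, this shows only that the change is compatible with a readable value on this core; the step starts from a limit and not from a number, so it gives a floor and leaves the true size of the step unknown. It also does not show whether the change carries from one core to another, since the same change on the other core cannot be read and there is no second size to set against this one: the limit of > 25000 nM in this assay, at which 3 of the 4 values shown sit.

As far as these compounds go, it remains open whether a longer chain such as n-hexyl, or a benzyl group, on the amine nitrogen would give a readable value in this assay on either core. From the compounds shown here alone, it also remains open how the size of this change would compare between the two cores if both ends of each step were numbers.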